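This account rests on a few compounds, and the source may have more. Where it says the series, first, only, none or still open, it means among the compounds named here.

Compound 1 `Cn1cc(C(=O)Nc2ccc(-c3ccccn3)c(C(F)(F)F)c2)c(=O)c2ccccc21` is one of two measured members of a small series sharing one core, the other being compound 2 `Cn1cc(C(=O)Nc2cnc(-c3ccccc3)c(C(F)(F)F)c2)c(=O)c2ccccc21`. In a physicochemical assay for solubility, in phosphate buffer, at pH 7.4 (a higher number here means a more soluble compound, a lower number a less soluble compound), compound 1 gives < 1 ug/mL, which is a limit of the assay rather than a number. In this assay compound 2 likewise gives < 1 ug/mL, again a limit. So compound 1 stands at the floor of what can be reported, and the one piece of evidence is simply (the limit of < 1 ug/mL in this assay, at which 2 of the 2 values shown sit); no measured step between two compounds exists here.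

Compound 3 `Cn1cc(C(=O)Nc2ccc(-c3ccncc3)c(C(F)(F)F)c2)c(=O)c2ccccc21` has not yet been measured in this assay. It differs from compound 1 in a single place: pyridin-4-yl in place of pyridin-2-yl on an aromatic carbon

Going by the values given here, with no measured step to lean on, the change from compound 1 to compound 3 is expected to move solubility only modestly upward, by about an at least 3.0-fold higher number from compound 1 to compound 3 (0.47 log units; beyond the scatter), although a limit for compound 1 leaves the starting point uncertain. Compound 3 is therefore estimated to give about 3 ug/mL in this assay, within a range of 0.5 ug/mL to 15 ug/mL.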

Compound 3, solubility: 7.9 ug/mL
Compound 3: middle estimate off by 2.6-fold (0.42 log units), on the low side; the range from low to high includes it.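

Exchanging pyridin-2-yl for pyridin-4-yl on this aromatic carbon, ortho to a trifluoromethyl group and para to a large group, leaves the atoms of the compound unchanged, since the same atoms are only joined differently. Even so, this assay records an at least 7.9-fold higher number from compound 1 to compound 3 (0.89 log units; beyond the scatter), a step beyond the scatter. This is the first readable step in the series, and it shows that this position can respond to a change as small as moving the nitrogen within the ring, something the earlier compounds could not show while they sat at the floor of the assay, so the real size of the step may be larger than the printed bound and remains unknown: the limit of < 1 ug/mL in this assay, at which 2 of the 3 values shown sit.

The compounds shown leave open whether pyridin-3-yl would behave more like pyridin-2-yl or pyridin-4-yl, so a single pair cannot yet show how the result depends on where the nitrogen sits. They also leave open how far this position could be taken by a group of another kind, such as an amine or a carboxylic acid, in place of the pyridine ring.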